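Amide to carbamoyl at the shared carbonyl: an expected gain

The source may report more compounds than this note shows. Statements on the series, on what has been measured and on what is new or still open speak of the compounds shown alone.

Measured compounds:
compound 1 `O=C(Nc1cccc(-n2cc(-c3ccncc3)c(-c3ccc(Cl)c(O)c3)n2)c1)Nc1cccc(C(F)(F)F)c1` gives 509 nM
compound 2 `COc1cc(-c2nn(-c3cccc(NC(=O)Nc4cc(C(F)(F)F)cc(C(F)(F)F)c4)c3)cc2-c2ccncc2)ccc1Cl` gives 144 nM
compound 3 `COc1cc(-c2nn(-c3cccc(NC(=O)c4cccc(C(F)(F)F)c4)c3)cc2-c2ccncc2)ccc1Cl` gives 555 nM

In a functional assay on HOP-92 cells (Homo sapiens) for inhibition, read by sulforhodamine B assay, with a stated time of 48 h (on this read-out lower numbers stand for stronger inhibition of growth and higher numbers for weaker inhibition of growth), compound 3 has the highest number of the three. Compound 1 gives 509 nM, and this lies within the scatter of the number for compound 3, so the two cannot be ordered. Among the compounds with values here, compound 2 gives 144 nM, a number beyond the scatter below that of compound 3; compound 2 differs from compound 3 at the same carbonyl carbon that is changed below, but no single-point step to it is available.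

Compound 4 `COc1cc(-c2nn(-c3cccc(NC(=O)Nc4ccc(Cl)c(Cl)c4)c3)cc2-c2ccncc2)ccc1Cl` is the untested compound. It differs from compound 3 in one place: (3,4-dichlorophenyl)amino in place of 3-(trifluoromethyl)phenyl on a carbonyl carbon. Cut one bond further out, the same difference reads (3-(trifluoromethyl)phenyl)carbonyl to (3,4-dichlorophenyl)carbamoyl.

Within the data shown here, no measured pair isolates this change, so the expected size of the step rests on compound 2, whose lower number 144 nM shows that a related substituent at this carbonyl can go with a lower number. Compound 4 is therefore expected to sit below compound 3 by a modest step, a 2.2-fold lower number from compound 3 to compound 4 (0.35 log units; beyond the scatter), though within a wide band. The estimate for compound 4 is 250 nM, between 90 nM and 700 nM.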

Compound 4, concentration for 50% growth inhibition: 151 nM
Compound 4: middle estimate off by 1.7-fold (0.22 log units), on the high side; low and high end bracket the measured number.
By their numbers in this assay, from the lowest: compounds 2 and 4 (each within the scatter of the next); then compounds 1 and 3 (each within the scatter of the next).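

Within the data shown here, this is the first single-place step at this carbonyl carbon: in this assay, putting (3,4-dichlorophenyl)amino in place of 3-(trifluoromethyl)phenyl gives a 3.7-fold lower number from compound 3 to compound 4 (0.57 log units; beyond the scatter), so on this core the exchange goes with stronger inhibition of growth. The step carries two differences at once, since the entering group brings an amide-type nitrogen with one hydrogen-bond donor while the ring exchanges its trifluoromethyl for two chlorines, and the step alone cannot assign the gain to either. Nothing measured here offers an explanation for the step.

The compounds shown leave open how the step divides between the added nitrogen and the change of ring substituents; (3-(trifluoromethyl)phenyl)amino or 3,4-dichlorophenyl on the same carbonyl carbon of the core of compound 3 would separate the two. Also open, from the compounds shown here alone, is whether an aromatic ring is needed on the nitrogen at all, a question that a cyclohexylamino group at this carbonyl carbon would address, and whether the step holds in cells other than those of this one read-out.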